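Lengthening a Chain by One Carbon

A few compounds are considered here, and "the series" means these few. Any claim that something is new, unique, unknown or untested is made for them only; others in the source may bear on it.

Compound 2 `CCCn1c(Cc2cc(OC)c(OC)c(OC)c2)nc2c(N)nc(F)nc21` has been tested in a functional assay on MCF7 cells (Homo sapiens) for antiproliferative activity (a lower number here means a stronger inhibitor, a higher number a weaker inhibitor), where compound 2 gives 25100 nM. Its nearest neighbour is compound 1 `CC#CCCn1c(Cc2cc(OC)c(OC)c(OC)c2)nc2c(N)nc(F)nc21`, which in this assay gives 37200 nM. Going by the values given here, the step of a 1.5-fold lower number from compound 1 to compound 2 (0.17 log units; within the scatter) lies within the scatter, so the two numbers cannot be told apart, and compound 2 stands level with the only other compound measured.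

Compound 3 `CCCCn1c(Cc2cc(OC)c(OC)c(OC)c2)nc2c(N)nc(F)nc21` has not yet been measured. It differs from compound 2 by methyl in place of hydrogen on a saturated chain carbon, three bonds along the chain from an aromatic nitrogen, which, cut one bond further out, reads propyl to butyl. Among the compounds with values here, the one measured step that bears on it is the exchange on the same chain, a 1.5-fold lower number from compound 1 to compound 2 (0.17 log units; within the scatter), which replaced prop-1-yn-1-yl with methyl without moving the number beyond the scatter. The entry of a methyl at the end of that chain is a smaller change than that, so no step beyond the scatter is expected in this assay in either direction.

Compound 3 is therefore estimated at 24000 nM, with a range of 10000 nM to 55000 nM. The step this estimate means is a 1.0-fold lower number from compound 2 to compound 3 (0.02 log units; within the scatter), expected to stay within the scatter.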

Compound 3, half-maximal inhibitory concentration: 24000 nM
Beside the measured number, compound 3's estimate shows no gap at the digits printed; the range from low to high includes it.
By their numbers in this assay, from the lowest: compounds 3, 2 and 1 (each within the scatter of the next).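

In this assay the step of a 1.0-fold lower number from compound 2 to compound 3 (0.02 log units; within the scatter) shows that, at this place on a saturated chain carbon, three bonds along the chain from an aromatic nitrogen, the entry of a methyl that turns propyl into butyl leaves the number where it was within the scatter. The step of a 1.6-fold lower number from compound 1 to compound 3 (0.19 log units; within the scatter) stays within the scatter as well, so ethyl in place of prop-1-yn-1-yl gives no readable change either, and compound 1, compound 2 and compound 3 cannot be told apart by this read-out. The data thus show that the measured chains on this nitrogen all give numbers of the same size, but nothing given here accounts for that.

What the compounds shown leave open is whether a longer chain such as hexyl, or a chain ending in an amine or a carboxylic acid, would move the number beyond the scatter in either direction. From the compounds shown here alone, it also remains open whether a chain of this kind would behave in the same way if the rest of the shared core were changed.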